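Swapping the Sulfonamide Substituent in a Kinase Inhibitor Series

The source may report more compounds than this note shows. Statements on the series, on what has been measured and on what is new or still open speak of the compounds shown alone.

In an assay for inhibition of 6-phosphofructo-2-kinase/fructose-2,6-bisphosphatase 3 (Homo sapiens), read by ADP-Glo, with a stated time of 2 h (on this read-out higher numbers stand for weaker inhibition and lower numbers for stronger inhibition), compound 3 `CN1CCC(NS(=O)(=O)c2ccccc2Nc2cc(-c3ccc4ccn(C)c4c3)c3nccnc3c2)C1` gives 33 nM, the second highest of the three numbers measured. Compound 1 `CN1CCC(CNS(=O)(=O)c2ccccc2Nc2cc(-c3ccc4ccn(C)c4c3)c3nccnc3c2)C1` gives 11 nM, and compound 2 `Cn1ccc2ccc(-c3cc(Nc4ccccc4S(N)(=O)=O)cc4nccnc34)cc21` gives 265 nM. All measured steps concern the sulfonamide nitrogen: a 24-fold higher number from compound 1 to compound 2 (1.38 log units; beyond the scatter), a 3.0-fold higher number from compound 1 to compound 3 (0.48 log units; beyond the scatter) and an 8.0-fold lower number from compound 2 to compound 3 (0.90 log units; beyond the scatter). Compound 4 `CN(Cc1cncnc1)S(=O)(=O)c1ccccc1Nc1cc(-c2ccc3ccn(C)c3c2)c2nccnc2c1` carries methyl((pyrimidin-5-yl)methyl)amino in place of (1-methylpyrrolidin-3-yl)amino on a sulfonyl sulfur. A substituent on that nitrogen, in compound 1 and compound 3, gives lower numbers than the bare hydrogen of compound 2, but the new group has no precedent among these compounds, so the direction of the step is uncertain. Compound 4 is expected to give 60 nM, between 15 nM and 250 nM. That estimate amounts to an expected 1.8-fold higher number from compound 3 to compound 4 (0.26 log units; within the scatter).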

Compound 4, half-maximal inhibitory concentration: 62 nM
Compound 4: the middle estimate sits 1.0-fold (0.01 log units) below what was measured; the measured number falls inside the stated range.
By their numbers in this assay, from the lowest: compound 1; then compounds 3 and 4 (each within the scatter of the next); then compound 2.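

On the sulfonyl sulfur, a group with a six-membered aromatic ring and no hydrogen-bond donor does as well as the pyrrolidine group, giving a 1.9-fold higher number from compound 3 to compound 4 (0.27 log units; within the scatter) in this assay. The substituted group still improves on plain amino, with a 4.3-fold lower number from compound 2 to compound 4 (0.63 log units; beyond the scatter), yet ((1-methylpyrrolidin-3-yl)methyl)amino stays ahead, with a 5.6-fold higher number from compound 1 to compound 4 (0.75 log units; beyond the scatter). Nothing available explains these steps.

Still open, from the compounds shown here alone, is what the nitrogen methyl and the pyrimidine ring each contribute. The (pyrimidin-5-yl)methylamino group without that methyl, or a benzyl(methyl)amino group, would separate the two.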